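This account rests on a few compounds, and the source may have more. Where it says the series, first, only, none or still open, it means among the compounds named here.

Compound 3, `O=c1c2cc(-c3ccnc4[nH]ccc34)sc2ncn1Cc1cccc(F)c1`: 13 nM
Compound 2, `COc1cccc(Cn2cnc3sc(-c4ccnc(N)c4)cc3c2=O)c1`: 18 nM
Compound 1, `COc1cccc(CN2CCc3cc(-c4ccc5[nH]ncc5c4)ccc3C2=O)c1`: 2060 nM

In an assay on isolated protein for inhibition of Rho-associated protein kinase 1 (Homo sapiens), read by radiometric assay and 33P incorporation, with a stated time of 40 min, in the presence of a further agent that is not named here (on this read-out higher numbers stand for weaker inhibition and lower numbers for stronger inhibition), compound 3 gives the lowest of the three numbers. Compound 2 sits within the scatter of compound 3, so the two cannot be ordered, while compound 1 stands far above both, beyond the scatter. Compound 4, `O=c1c2cc(-c3ccnc4[nH]ccc34)sc2ncn1Cc1cccc(C(F)(F)F)c1`, is not yet measured. It differs from compound 3 by trifluoromethyl in place of fluoro on an aromatic carbon. Within the data shown here, no two measured compounds differ in one place, so the size of such a step cannot be read from the data; the expectation rests on compound 3 alone. The step from compound 3 to compound 4 is expected to be small, a 1.5-fold higher number from compound 3 to compound 4 (0.19 log units; within the scatter), with no direction beyond the scatter. Compound 4 is therefore estimated at 20 nM, within a range of 6 nM to 70 nM.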

Compound 4, half-maximal inhibitory concentration: 110 nM
Estimate against measurement, compound 4: 5.5-fold (0.74 log units) below; the whole stated range lies below it.
By their numbers in this assay, from the lowest: compounds 3 and 2 (each within the scatter of the next); then compound 4; then compound 1.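

Trifluoromethyl in place of fluoro on this six-membered aromatic ring of carbon only gives an 8.5-fold higher number from compound 3 to compound 4 (0.93 log units; beyond the scatter), the first change at a single place among these compounds. Among these compounds, it shows that inhibition at this position responds to the group it carries, which the earlier compounds, differing in more than one place, could not show. No measurement given here accounts for this step.

From the compounds shown here alone, whether chloro or nitrile at this position would stay close to compound 3 or move towards compound 4 remains open. So does the outcome with a plain hydrogen there.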